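The source may hold more compounds than are shown below. What is called first, only, known or untested is meant among the compounds shown, and "the series" means these compounds.

Working notes on the series. The common core carries a benzyl carbamate in compound 2 `COc1cc2nc(N3CCN(C(=O)OCc4ccccc4)[C@@H]4CCCC[C@@H]43)nc(N)c2cc1OC` and a pivaloyl amide in compound 1 `COc1cc2nc(N3CCN(C(=O)C(C)(C)C)[C@H]4CCCC[C@H]43)nc(N)c2cc1OC`. For the measured compounds named here, in a functional assay (strain Wistar) for antagonist activity at Alpha-1D adrenergic receptor (Rattus norvegicus), with a stated time of 30 min, in the presence of a further agent that is not named here (a higher number here means weaker binding, a lower number tighter binding), compound 2 gives 0.525 nM, the lowest of the two numbers so far; in this assay compound 1 gives 141 nM, a gap beyond the scatter, but the two differ in more than one respect, so no single step can be read from them. Compound 3 `COc1cc2nc(N3CCN(C(=O)OCc4ccccc4)[C@H]4CCCC[C@H]43)nc(N)c2cc1OC` is the mirror image of compound 2: the two compounds have the same atoms and bonds and differ only in configuration as drawn: 2 of 2 stereo elements differ (all stereocentres are inverted: mirror images); a stereocentre at a saturated ring carbon is drawn R in compound 2 and S in compound 3; a stereocentre at a saturated ring carbon is drawn S in compound 2 and R in compound 3. Going by the values given here, no step between measured compounds is available for this change. Inversion of both ring stereocentres is expected to weaken binding in this assay, by a step of the order of a 38-fold higher number from compound 2 to compound 3 (1.58 log units; beyond the scatter), with wide uncertainty since nothing measured isolates it. For compound 3 in this assay the estimate is 20 nM, within 1.5 nM to 300 nM.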

Compound 3, dissociation constant: 240 nM
The estimate for compound 3 lay 12-fold (1.08 log units) below the measured number; measured number inside the range.
By their numbers in this assay, from the lowest: compound 2; then compounds 1 and 3 (each within the scatter of the next).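

In this assay inversion of both ring stereocentres alone gives a 460-fold higher number from compound 2 to compound 3 (2.66 log units; beyond the scatter), and this step can be put down to configuration because nothing else separates the pair: the fact that compounds 2 and 3 differ only in the configuration as drawn. With the configuration of compound 3 held, benzyloxy in place of tert-butyl on a carbonyl carbon gives a 1.7-fold higher number from compound 1 to compound 3 (0.23 log units; within the scatter), so in this configuration the two groups cannot be told apart. Compound 1 and compound 2 differ in both respects at once, and compound 3 now separates the two changes.

The compounds shown leave open what the same group change does in the configuration of compound 2, and what inverting only one of the two ring stereocentres does. On these data alone, it is also open whether a longer chain or an amine on the carbonyl carbon would show the same dependence on configuration.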